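The compounds below may be only part of what the source reports. "The series", "measured", "known", "first", "only" and "open" are said of these compounds alone.

Measured in a functional assay on HCT-116 cells (Homo sapiens) for cytotoxicity, read by MTT assay, with a stated time of 72 h; a lower number here means a stronger inhibitor, a higher number a weaker inhibitor:
- compound 1 `N[C@H]1CC[C@H](Nc2c(C(=O)NCc3ccco3)nc(Br)c3cccnc23)CC1`: > 10000 nM
- compound 2 `CN(C)CCCNc1c(C(=O)NCc2ccc(F)cc2)nc(Br)c2cccnc12`: > 10000 nM

Neither entry is a number. The value of compound 1, > 10000 nM, is a limit of the assay. Compound 2 likewise has only a limit, > 10000 nM. The whole measured set therefore sits in one place: the limit of > 10000 nM in this assay, at which 2 of the 2 values shown sit.

Next in the series is compound 3 `CNCCCNc1c(C(=O)NCc2ccc(F)cc2)nc(Br)c2cccnc12`. Its difference from compound 2 is hydrogen in place of methyl on an amine nitrogen, with dimethylamino becoming methylamino. Among the measured compounds shown here, no measured pair isolates this change, so the data give no direct size for it. In this assay, no step beyond the scatter is expected. This expectation rests on compound 2 at > 10000 nM and on the small size of the change. Another report at the limit is the likeliest outcome, although a measurable value cannot be ruled out. The estimated a number no higher from compound 2 to compound 3 (the limit leaves the size open) is expected to stay within the scatter. For compound 3 the expected value is 10000 nM, with an estimated range of 3000 nM to 30000 nM.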

Compound 3, half-maximal inhibitory concentration: 9000 nM
For compound 3 the middle estimate is 1.1-fold (0.05 log units) above the measured one; the range from low to high includes it.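

In this assay, among the compounds shown here, compound 3 gives 9000 nM, the first value that is an actual number rather than a limit, so this end of the side chain now has a reading that later changes can be set against. Hydrogen in place of methyl on the amine nitrogen, with dimethylamino becoming methylamino, gives an at least 1.1-fold lower number from compound 2 to compound 3 (0.04 log units; that floor lies within the scatter); this is a floor and not a measured size, so the data show no step beyond the scatter, while the true size of the change stays unknown. Compound 2 is itself only a limit of the assay, and the set as a whole still sits largely at that one place: the limit of > 10000 nM in this assay, at which 2 of the 3 values shown sit.

The compounds shown leave open how far the response at this position can move, since one number and one floor cannot define a trend for the amine nitrogen. A plain amino group or an ethyl group on that nitrogen, or a longer chain carrying the methylamino group, would show whether the values move clearly away from the limit or stay near the reading of compound 3.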